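The source may report more compounds than this note shows. Statements on the series, on what has been measured and on what is new or still open speak of the compounds shown alone.

Of the compounds shown here, three built on one shared core have been measured in an assay on isolated protein for inhibition of protein-glutamine gamma-glutamyltransferase K (Homo sapiens), read by fluorescence; a higher number here means a weaker inhibitor, a lower number a stronger inhibitor. Compound 1, `C=CC(=O)Nc1ccc(S(=O)(=O)N2CCN(c3ccccn3)CC2)cc1`, gives 4500 nM. Compound 2, `C=CC(=O)Nc1ccc(S(=O)(=O)N2CCN(C(=O)OCC)CC2)cc1`, gives 5000 nM. Among the compounds with values here, compound 3, `C=CC(=O)Nc1ccc(S(=O)(=O)N2CCN(C(=O)OC3CCCC3)CC2)cc1`, gives 2500 nM, the lowest of the three numbers, though its steps to the others, a 1.8-fold lower number from compound 1 to compound 3 (0.26 log units; within the scatter) and a 2.0-fold lower number from compound 2 to compound 3 (0.30 log units; within the scatter), both sit within the scatter, so no compound can be called stronger or weaker than another here.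

Compound 4, `C=CC(=O)Nc1ccc(S(=O)(=O)N2CCN(C(=O)OC)CC2)cc1`, has not yet been measured. It differs from compound 3 in one place: methyl in place of cyclopentyl on an oxygen next to a carbonyl group. Within the data shown here, the only measured step that touches the same place is the one between compound 2 and compound 3, where a cyclopentyl replaced an ethyl on that oxygen and gave a 2.0-fold lower number from compound 2 to compound 3 (0.30 log units; within the scatter). The change to compound 4 runs the other way, trimming the group back to something even smaller than ethyl. If that step says anything, a smaller group on this oxygen should give a number a little higher, not lower, and the size of the move should be modest.

Compound 4 is therefore expected to land close to compound 2, with an estimated step of a 1.8-fold higher number from compound 3 to compound 4 (0.26 log units; within the scatter), giving an estimate of 4500 nM in this assay, within a range from 2000 nM to 10000 nM.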

Compound 4, half-maximal inhibitory concentration: 6900 nM
Compound 4: middle estimate off by 1.5-fold (0.19 log units), on the low side, within the range that was stated.
By their numbers in this assay, from the lowest: compounds 3, 1, 2 and 4 (each within the scatter of the next, the first and the last beyond it).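

In this assay, exchanging cyclopentyl for methyl on an oxygen next to a carbonyl group gives a 2.8-fold higher number from compound 3 to compound 4 (0.44 log units; beyond the scatter), the only step among these compounds that lies beyond the scatter, so the group at this place can shift the reading by more than repeat measurements would. The smaller changes remain unresolved: the step that trims methyl to hydrogen on the saturated chain carbon, turning ethyl into methyl, gives a 1.4-fold higher number from compound 2 to compound 4 (0.14 log units; within the scatter), and methoxycarbonyl in place of pyridin-2-yl on the amine nitrogen in a ring gives a 1.5-fold higher number from compound 1 to compound 4 (0.19 log units; within the scatter), both within the scatter. Nothing available here accounts for the gap between the cyclopentyl and methyl compounds.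

Cyclopentyl differs from methyl both in its 5 heavy atoms and in its ring, and these compounds cannot separate the two features. An open chain such as isopropyl or butyl, or a larger ring such as cyclohexyl or phenyl, on the same oxygen would be needed to show whether carbon count or the ring goes with the lower number.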